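Chain lengthening on the anilino-type amine of a shared core

A few compounds are considered here, and "the series" means these few. Any claim that something is new, unique, unknown or untested is made for them only; others in the source may bear on it.

Measured compounds:
compound 1, `C=CCNc1nn2c(=O)cc(C(F)(F)F)nc2s1`, 890 nM
compound 2, `CCCNc1nn2c(=O)cc(C(F)(F)F)nc2s1`, 310 nM
compound 3, `CCCCNc1nn2c(=O)cc(C(F)(F)F)nc2s1`, 710 nM

In an ADME assay on cells for inhibition of Intestinal-type alkaline phosphatase (Homo sapiens), read by luminescence, with stated times of 7 min and 20 min (a higher number here means a weaker inhibitor, a lower number a stronger inhibitor), compound 3 sits second highest of the three numbers. Its nearest neighbour is compound 1, with which it lies within the scatter; its furthest is compound 2, the step of a 2.3-fold higher number from compound 2 to compound 3 (0.36 log units; beyond the scatter) being beyond the scatter. Compound 4, `CCCCCNc1nn2c(=O)cc(C(F)(F)F)nc2s1`, is not yet measured. It differs from compound 3 by methyl in place of hydrogen on a saturated chain carbon, four bonds along the chain from a nitrogen on an aromatic ring, so the chain grows from propyl to butyl.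

The step that bears on this is the preceding chain extension, a 2.3-fold higher number from compound 2 to compound 3 (0.36 log units; beyond the scatter), which moved the number upward by a modest amount. Within the data shown here, no second extension step is available to test whether that trend continues; the single step is the only guide. On that basis a further modest rise, or a change within the scatter, is expected for compound 4 in this assay, giving an estimated step of a 1.5-fold higher number from compound 3 to compound 4 (0.19 log units; within the scatter). Compound 4 is therefore estimated at 1100 nM, with a range from 500 nM to 2400 nM.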

Compound 4, half-maximal inhibitory concentration: 760 nM
For compound 4 the middle estimate is 1.4-fold (0.16 log units) above the measured one, and the stated range covers the measured number.
By their numbers in this assay, from the lowest: compound 2; then compounds 3, 4 and 1 (each within the scatter of the next).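

In this assay, adding methyl in place of hydrogen four bonds along the chain does not repeat the rise seen one carbon earlier: a 1.1-fold higher number from compound 3 to compound 4 (0.03 log units; within the scatter) stays within the scatter. The gap to the shorter chain persists, with a 2.5-fold higher number from compound 2 to compound 4 (0.39 log units; beyond the scatter) beyond the scatter, so among these four compounds the strongest inhibition belongs to compound 2 alone, and lengthening past it gives no further change that can be told from scatter. The vinyl comparison, a 1.2-fold lower number from compound 1 to compound 4 (0.07 log units; within the scatter) within the scatter, puts compound 4 level with the unsaturated chain as well.

On these data alone, it remains open whether a still longer chain stays level. Also open, as far as these compounds go, is whether a branched chain, a cyclopropyl ring or a hydroxyl group on the chain could match or pass compound 2 at 310 nM in this assay and nothing given here accounts for the levelling.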